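A few compounds are considered here, and "the series" means these few. Any claim that something is new, unique, unknown or untested is made for them only; others in the source may bear on it.

Compound 1 `COc1cc(OC)c(/C=C/S(=O)(=O)Cc2cc(OC)c(OC)c(OC)c2)c(OC)c1` gives > 20000 nM in a functional assay on DLD-1 cells (Homo sapiens) for antiproliferative activity, read by trypan blue exclusion; a higher number here means a weaker inhibitor, a lower number a stronger inhibitor; this is a limit of the assay, not a number.
Compound 2 `COc1cc(OC)c(/C=C/S(=O)(=O)Cc2ccc(C(=O)O)cc2)c(OC)c1` gives 15000 nM in this assay.
Compound 3 `COc1ccc(CS(=O)(=O)/C=C/c2cc(OC)c(OC)cc2OC)cc1` gives > 20000 nM in this assay, again a limit rather than a number.

Among these three, compound 2 is the only one with a measured number; the other two values sit at the limit of > 20000 nM in this assay, at which 2 of the 3 values shown sit, so compound 2 cannot be ranked against them beyond saying that it was measurable at all, and even so it is a weak inhibitor.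

Compound 4 `COc1ccc(CS(=O)(=O)/C=C/c2c(OC)cc(OC)cc2OC)cc1` differs from compound 2 in one place: methoxy in place of carboxy on an aromatic carbon. Going by the values given here, no pair of measured compounds shows this exact change, so its effect can only be guessed. Compound 3 carries the same 4-methoxyphenyl group on a differently substituted core and reaches only a limit, which suggests the change does not help. The expected step is a 1.3-fold higher number from compound 2 to compound 4 (0.12 log units; within the scatter), a shift toward weaker inhibition that may not clear the scatter. Compound 4 is therefore estimated at 20000 nM, between 8000 nM and 50000 nM, with a fair chance that only a limit is reported.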

Compound 4, half-maximal inhibitory concentration: 40 nM
For compound 4 the middle estimate is 500-fold (2.70 log units) above the measured one, outside the stated range (below it).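

In this assay, putting methoxy in place of carboxy on this aromatic carbon, para to a large group, gives a 380-fold lower number from compound 2 to compound 4 (2.57 log units; beyond the scatter). Compound 2 alone made this ring look like a poor place to start, but this single pair shows that the group at this position can separate a weak inhibitor from a strong one. The change swaps carboxy, with its hydrogen-bond donor, for methoxy, which has none, yet one pair cannot show whether that donor is what matters, and the other two compounds cannot help, as their values are limits: the limit of > 20000 nM in this assay, at which 2 of the 4 values shown sit.

The compounds shown leave open whether methoxy itself is needed here or whether a hydroxy group, an amine or a fluorine would serve as well. They also leave open how a longer chain, such as ethoxy, would fare at this position.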